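A thiazole in place of furan beside the amine

The compounds below may be only part of what the source reports. "The series", "measured", "known", "first", "only" and "open" are said of these compounds alone.

Compound 3 `C[C@H]1[C@H](NCc2ccco2)C[C@H]2C[C@@H]1C2(C)C` carries furan-2-yl on a saturated chain carbon bound to an amine nitrogen. In an ADME assay on MDCK cells (Canis lupus familiaris) for cytotoxicity, read by microscopy, with a stated time of 48 h (on this read-out higher numbers stand for lower toxicity in this test and lower numbers for higher toxicity in this test), compound 3 gives 50000 nM, the highest of the two numbers shown. Compound 1 `C[C@H]1[C@H](NCc2cccs2)C[C@H]2C[C@@H]1C2(C)C` gives 25000 nM in this assay, and a 2.0-fold higher number from compound 1 to compound 3 (0.30 log units; within the scatter). Compound 2 `C[C@H]1[C@H](NCc2cncs2)C[C@H]2C[C@@H]1C2(C)C` gives a limit in this assay, > 100000 nM. Compound 4 `C[C@H]1[C@H](NCc2nccs2)C[C@H]2C[C@@H]1C2(C)C` is not yet measured; it differs from compound 3 in one place: 1,3-thiazol-2-yl in place of furan-2-yl on a saturated chain carbon bound to an amine nitrogen. Among the compounds with values here, two measured steps bear on a thiazole entering at this place: an at least 4.0-fold higher number from compound 1 to compound 2 (0.60 log units; beyond the scatter) and an at least 2.0-fold lower number from compound 2 to compound 3 (0.30 log units; that floor lies within the scatter). Compound 4 is therefore expected to give a higher number, a 2.0-fold higher number from compound 3 to compound 4 (0.30 log units; within the scatter), and may itself reach (the limit of > 100000 nM in this assay, at which 1 of the 3 values shown sits). The estimate for compound 4 in this assay is 100000 nM, between 40000 nM and 250000 nM.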

Compound 4, minimum cytotoxic concentration: > 100000 nM
Compound 4 was reported as a limit; the forecaster's own chance of this, stated with the estimate: 50%; the middle value sits exactly at the limit.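

A second thiazole, 1,3-thiazol-2-yl, now joins 1,3-thiazol-5-yl at the top of the read-out, and compound 4 is reported as a limit, not a number, in this assay for this position. Set against thiophen-2-yl, the change gives an at least 4.0-fold higher number from compound 1 to compound 4 (0.60 log units; beyond the scatter), whereas set against furan-2-yl it gives an at least 2.0-fold higher number from compound 3 to compound 4 (0.30 log units; that floor lies within the scatter), so only a floor is known. The step between the two thiazoles cannot be read, as both compounds end at a limit: the limit of > 100000 nM in this assay, at which 2 of the 4 values shown sit.

On these data alone, it remains open how far the two thiazoles truly differ, and whether a pyridin-2-yl group or a carboxylic acid on this saturated chain carbon would also reach this limit.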